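Swapping Phenyl for Thiophen-3-yl on the Carbonyl of Compound 1

The source may hold more compounds than are shown below. What is called first, only, known or untested is meant among the compounds shown, and "the series" means these compounds.

Compound 1, `COc1ccc(-c2cc3ccccc3nc2/C=C/C(=O)c2ccccc2)cc1`: 4040 nM
Compound 2, `COc1ccc(C(=O)/C=C/c2nc3ccccc3cc2-c2ccc(OC)cc2)cc1`: 7380 nM
Compound 3, `COc1ccc(-c2cc3ccccc3nc2/C=C/C(=O)c2cccs2)cc1`: 1030 nM

These three compounds share one core and were tested in a functional assay on MCF7 cells (Homo sapiens) for antiproliferative activity, read by XTT assay, with a stated time of 72 h; on this read-out lower numbers stand for stronger inhibition and higher numbers for weaker inhibition. Compound 1 stands second highest of the three numbers: compound 2 is nearest, with a 1.8-fold higher number from compound 1 to compound 2 (0.26 log units; within the scatter), while compound 3 is furthest, with a 3.9-fold lower number from compound 1 to compound 3 (0.59 log units; beyond the scatter). Compound 4, `COc1ccc(-c2cc3ccccc3nc2/C=C/C(=O)c2ccsc2)cc1`, is not yet measured. It differs from compound 1 as follows: thiophen-3-yl in place of phenyl on a carbonyl carbon. Among the measured compounds shown here, the one measured step that bears on this is the step from compound 1 to compound 3, a 3.9-fold lower number from compound 1 to compound 3 (0.59 log units; beyond the scatter), where thiophen-2-yl took the same place on the carbonyl carbon. Thiophen-3-yl is a close structural relative of thiophen-2-yl, so a modest lowering of the number is expected, with less certainty than for the measured step. For compound 4 the estimate is 2000 nM, ranging from 800 nM to 5000 nM, which amounts to an expected step of a 2.0-fold lower number from compound 1 to compound 4 (0.31 log units; beyond the scatter).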

Compound 4, half-maximal inhibitory concentration: 6010 nM
The estimate for compound 4 lay 3.0-fold (0.48 log units) below the measured number; measured number outside the range, above it.
By their numbers in this assay, from the lowest: compound 3; then compounds 1, 4 and 2 (each within the scatter of the next).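

In this assay, the two thiophene attachments on this carbonyl carbon are not interchangeable: thiophen-3-yl in place of thiophen-2-yl gives a clear change (a 5.8-fold higher number from compound 3 to compound 4 (0.77 log units; beyond the scatter)). The advantage of compound 3 therefore does not extend to every thiophene, since thiophen-3-yl stays within the scatter of both phenyl (a 1.5-fold higher number from compound 1 to compound 4 (0.17 log units; within the scatter)) and 4-methoxyphenyl (a 1.2-fold lower number from compound 2 to compound 4 (0.09 log units; within the scatter)). No measurement here explains this difference between the two thiophenes. Still open, as far as these compounds go, is how furan-2-yl, pyridin-2-yl or a chain ending in an amine would behave on this carbonyl carbon.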